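The source may hold more compounds than are shown below. What is called first, only, known or untested is meant among the compounds shown, and "the series" means these compounds.

Compound 2 has the structure `COc1ccc2nc(-c3ccc(NC(=O)NCc4ccccc4)cc3)sc2c1`; it carries a urea bearing a benzylamino group on the shared core. In a functional assay on U-937 cells (Homo sapiens) for cytotoxicity, read by MTT assay, with a stated time of 2 days (a lower number here means a stronger inhibitor, a higher number a weaker inhibitor), compound 2 gives > 50000 nM, which is a limit of the assay rather than a measured number. Of the two entries known here, compound 2 is therefore the only one with even a bound, and it sits at the limit of > 50000 nM in this assay, at which 1 of the 2 values shown sits. Compound 1, with the structure `COc1ccc2nc(-c3ccc(N=C(NC4CCCCC4)NC4CCCCC4)cc3)sc2c1`, stands at "not determined" (no result reported) in this assay, so no number is available for it either.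

Compound 3, with the structure `COc1ccc2nc(-c3ccc(NC(=O)C4CC4)cc3)sc2c1`, is the compound still to be measured. It differs from compound 2 in one place: cyclopropyl in place of benzylamino on a carbonyl carbon. The urea thus becomes a small amide, and the group counted as leaving is larger than the one entering.

Among the measured compounds shown here, no step between two measured compounds is known, so there is nothing to scale this change against. Given that compound 2 reached only > 50000 nM, the expectation is that compound 3 likewise shows little cytotoxicity, and the estimated step from compound 2 to compound 3 is a step that the limit leaves unreadable from compound 2 to compound 3, no clear change beyond the scatter. Compound 3 is expected to give about 60000 nM, within a range from 15000 nM to 200000 nM, with a real chance that only a limit is reported.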

Compound 3, half-maximal inhibitory concentration: > 50000 nM
Compound 3: no number, only a limit (the forecaster's own chance of this, stated with the estimate: 70%); the middle value lies beyond the limit too.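

Among the compounds shown here, compound 2 and compound 3 both stop at a limit of this assay rather than at a measured number, so no step from one to the other can be read. The compounds shown leave open whether any group on this carbonyl carbon gives a measurable cytotoxic effect on these cells, and how large that effect would be.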